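A stereocentre drawn as R in the series

This account rests on a few compounds, and the source may have more. Where it says the series, first, only, none or still open, it means among the compounds named here.

In an ADME assay on MT4 cells (Homo sapiens) for cytotoxicity, read by MTT assay, with a stated time of 5 days (a lower number here means that less compound is tolerated, a higher number that more compound is tolerated), compound 1 `COc1cc(-c2ccc(C#N)cc2)ccc1[C@@H](O)c1ccnc(Nc2ccc(C#N)cc2)n1` gives 33100 nM and compound 2 `N#Cc1ccc(Nc2nccc([C@H](O)c3ccc(-c4ccc(C#N)cc4)cc3Cl)n2)cc1` gives 28100 nM. Compound 3 `N#Cc1ccc(Nc2nccc(C(O)c3ccc(-c4ccc(C#N)cc4)cc3C(F)(F)F)n2)cc1` gives 11400 nM, the lowest of the three numbers and beyond the scatter from both others.

Compound 4 `N#Cc1ccc(Nc2nccc([C@H](O)c3ccc(-c4ccc(C#N)cc4)cc3C(F)(F)F)n2)cc1` differs from compound 3 only in its stereo drawing: the two compounds have the same atoms and bonds; at least one stereo element is drawn with a configuration in one of them and without one in the other: 1 of 1 stereo elements differ; a stereocentre at a saturated chain carbon is drawn without a configuration in compound 3 and R in compound 4. Within the data shown here, the atoms and bonds stay the same, and no measured pair isolates a change of this kind. Among the measured compounds shown here, the one measured step, a 1.2-fold lower number from compound 1 to compound 2 (0.07 log units; within the scatter), is an exchange of chloro for methoxy and stays within the scatter, so it gives no direct guide to size or direction here. The estimate therefore rests on compound 3 at 11400 nM, since compound 4 has the same atoms and bonds.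

No shift beyond the scatter is expected, and the estimated step is a 1.1-fold higher number from compound 3 to compound 4 (0.06 log units; within the scatter). Compound 4 is expected at 13000 nM, with an estimated range of 6500 nM to 27000 nM.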

Compound 4, half-maximal cytotoxic concentration: 24100 nM
The estimate for compound 4 lay 1.9-fold (0.27 log units) below the measured number, and the stated range covers the measured number.
By their numbers in this assay, from the lowest: compound 3; then compounds 4, 2 and 1 (each within the scatter of the next).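

In this assay, among these compounds, a change of stereo drawing alone now carries a step beyond the scatter, a 2.1-fold higher number from compound 3 to compound 4 (0.33 log units; beyond the scatter), which no earlier pair could show. The only structural difference to point to at this carbon is this: the fact that one of compounds 3 and 4 is drawn with a defined configuration and the other without, at the place where they differ. With the R drawing, the aromatic substituent makes no difference beyond the scatter, a 1.2-fold lower number from compound 2 to compound 4 (0.07 log units; within the scatter) and a 1.4-fold lower number from compound 1 to compound 4 (0.14 log units; within the scatter), so trifluoromethyl alone does not set compound 3 apart from compounds 1 and 2.

On these data alone, the effect of an S configuration at this saturated chain carbon remains open. As far as these compounds go, it also remains open whether an amine or a carboxylic acid in place of trifluoromethyl on the aromatic carbon would stay within the scatter of compound 4.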